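Acetoxy to benzoyloxy on a second core

The source may hold more compounds than are shown below. What is called first, only, known or untested is meant among the compounds shown, and "the series" means these compounds.

Compound 1 `CCC(/C=C(\COC(C)=O)C(=O)c1ccc(OC)cc1)CC` gives 9500 nM in a functional assay on NB-4 cells (Homo sapiens) for inhibition, read by XTT assay, with a stated time of 48 h; on this read-out lower numbers stand for stronger inhibition and higher numbers for weaker inhibition. Compound 2 `CCC(/C=C(\COC(=O)c1ccccc1)C(=O)c1ccc(OC)cc1)CC` carries phenyl in place of methyl on a carbonyl carbon and in this assay compound 2 gives 26800 nM, a step of a 2.8-fold higher number from compound 1 to compound 2 (0.45 log units; beyond the scatter). Compound 3 `C=C(C(=O)c1ccc(OC)cc1)C(OC(C)=O)c1ccccc1F` rests on a different core; the difference between the two cores is not broken down here. In this assay compound 3 gives 9500 nM, level with compound 1 and within the scatter of it. Compound 4 `C=C(C(=O)c1ccc(OC)cc1)C(OC(=O)c1ccccc1)c1ccccc1F` is not yet measured; against compound 3 it shows (phenyl in place of methyl on a carbonyl carbon), the same change as from compound 1 to compound 2, at a place described in the same words. For compound 4 the expected step is a 2.5-fold higher number from compound 3 to compound 4 (0.40 log units; beyond the scatter), resting on the step of a 2.8-fold higher number from compound 1 to compound 2 (0.45 log units; beyond the scatter) seen for the same change. Compound 4 is expected near 24000 nM, between 10000 nM and 55000 nM, with the untested second core as the open point.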

Compound 4, half-maximal inhibitory concentration: 14300 nM
Compound 4: the middle estimate sits 1.7-fold (0.22 log units) above what was measured, and the stated range covers the measured number.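

In this assay the change from acetoxy to benzoyloxy on the core of compound 3 gives a 1.5-fold higher number from compound 3 to compound 4 (0.18 log units; within the scatter). The two cores cannot be told apart for this change: the same change on two cores in this assay, a 2.8-fold higher number (0.45 log units; beyond the scatter) from compound 1 to compound 2 and a 1.5-fold higher number (0.18 log units; within the scatter) from compound 3 to compound 4, 1.9-fold (0.27 log units) apart, within the scatter of two such steps. This shows that the step seen on the core of compound 1 is compatible with the one on the core of compound 3, but it does not show that the two are the same size, and two pairs set no rule for any other core.

Still open, on these data alone, is how a longer chain or an amine on that carbonyl carbon would read in this assay and whether phenyl in place of methyl gives a comparable step on a third core.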